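This account rests on a few compounds, and the source may have more. Where it says the series, first, only, none or still open, it means among the compounds named here.

Measured so far:
compound 1, `Cc1c(OCCCCOCOc2ccc(C(=O)O)cc2)ccc(C(=O)CC2CCCC2)c1O`, 46.9%;
compound 2, `Cc1cc(OCCCCOc2ccc(C(=O)CC3CCCC3)c(O)c2C)ccc1C(=O)O`, 23.7%;
compound 3, `COC(=O)c1ccc(OCCCCOc2ccc(C(=O)CC3CCCC3)c(O)c2C)cc1`, 22%.

All three numbers come from an assay on HEK293 cells for positive allosteric modulation of metabotropic glutamate receptor 3 (Rattus norvegicus), read by thallium flux, with a stated time of 2.5 min; on this read-out lower numbers stand for smaller maximal responses and higher numbers for larger maximal responses. Compound 3 has the lowest of the three values, but its neighbour compound 2 sits only a number 1.7 percentage points lower from compound 2 to compound 3 (within the scatter) away, which is within the scatter, so the two cannot be told apart; only compound 1 stands clearly apart, with compound 3 lying a number 24.9 percentage points lower from compound 1 to compound 3 (beyond the scatter).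

The next compound, compound 4, `Cc1c(OCCCCOc2ccc(C(=O)O)cc2F)ccc(C(=O)CC2CCCC2)c1O`, differs from compound 3 in one place: 4-carboxy-2-fluorophenyl in place of 4-(methoxycarbonyl)phenyl on an oxygen on a saturated carbon. Going by the values given here, the step that bears most directly on this change is the one from compound 2 to compound 3, where a free carboxylic acid on the terminal aryl group was traded for a methyl ester and the response moved only a number 1.7 percentage points lower from compound 2 to compound 3 (within the scatter), within the scatter. The larger steps, a number 23.2 percentage points lower from compound 1 to compound 2 (beyond the scatter) and a number 24.9 percentage points lower from compound 1 to compound 3 (beyond the scatter), both start from compound 1 and involve the longer linking unit rather than the acid or ester itself, so they say little about the present exchange. A step for compound 4 of a number 3 percentage points higher from compound 3 to compound 4 (within the scatter) is therefore expected, that is, nothing beyond the scatter. For compound 4 the estimate is 25%, with a range from 12% to 40%.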

Compound 4, largest response reached (reported as percent of maximum), in percent of the reference or control that the assay uses: 31.2%
Compound 4: middle estimate off by 6.2 percentage points, on the low side, and the stated range covers the measured number.
By their numbers in this assay, from the lowest: compounds 3, 2 and 4 (each within the scatter of the next); then compound 1.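

In this assay, putting 4-carboxy-2-fluorophenyl in place of 4-(methoxycarbonyl)phenyl on this oxygen gives a number 9.2 percentage points higher from compound 3 to compound 4 (within the scatter) and putting it in place of 4-carboxy-3-methylphenyl gives a number 7.5 percentage points higher from compound 2 to compound 4 (within the scatter) so the three aryl groups cannot be told apart, even though they now include a fluorine-bearing acid as well as a methyl-bearing acid and a methyl ester. Going by these compounds alone, exchanging (4-carboxyphenoxy)methyl for the same fluorinated group gives a number 15.7 percentage points lower from compound 1 to compound 4 (beyond the scatter) and so compound 4 joins compound 2 and compound 3 in standing clearly apart from compound 1, which leaves (4-carboxyphenoxy)methyl as the only group here with a response separated from the others. No measurement is at hand that would account for any of these steps.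

From the compounds shown here alone, it remains open whether a plain 4-carboxyphenyl, a chlorine in place of the fluorine or a tetrazole in place of the carboxylic acid would read apart from compound 4 in this assay at this position. Also open, going by these compounds, is whether a longer chain or an amine on this oxygen would reach the response of compound 1 or stay with the other three.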